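A few compounds are considered here, and "the series" means these few. Any claim that something is new, unique, unknown or untested is made for them only; others in the source may bear on it.

Compound 2 `CC(C(=O)N1CCN(c2ccc(F)cc2)CC1)N1C(=O)CCC1=O` was tested in a functional assay on the whole organism (strain Swiss) with Mus musculus as the target, in the maximal electroshock model, with a stated time of 0.5 h, at a dose of 300 mg/kg by the intraperitoneal route (a higher number here means a stronger effect of the compound at the dose given, a lower number a weaker effect), and gave 50%. Among the measured compounds shown here, that is the higher of the two numbers measured so far. Its nearest companion, compound 1 `CCC(C(=O)N1CCN(c2ccccc2Cl)CC1)N1C(=O)CCC1=O`, gave 25% in this assay, a gap beyond the usual scatter. Compound 3 `CC(C(=O)N1CCN(c2ccccc2Cl)CC1)N1C(=O)CCC1=O` has not yet been measured. It differs from compound 2 in one place: 2-chlorophenyl in place of 4-fluorophenyl on an amine nitrogen in a ring. For the measured compounds named here, no step between two measured compounds matches this change, so the size of the effect is uncertain. Still, a fall rather than a rise is expected, because compound 1 also carries a 2-chlorophenyl group on an amine nitrogen in a ring and gives only 25%, even though compound 1 differs from compound 3 elsewhere as well. For compound 3 the expected result in this assay is 35%, within a range from 10% to 60%. That estimate amounts to an expected step of a number 15 percentage points lower from compound 2 to compound 3 (beyond the scatter), a moderate decrease.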

Compound 3, a percentage reported as activity, at one dose (the size of the read-out at that dose, not a potency): 0%
Compound 3: the middle estimate sits 35 percentage points above what was measured, outside the stated range (below it).
By their numbers in this assay, from the lowest: compound 3; then compound 1; then compound 2.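

In this assay, among the compounds shown here, 2-chlorophenyl in place of 4-fluorophenyl on the amine nitrogen in the ring gives the first direct reading of this change, and it is a large one: a number 50 percentage points lower from compound 2 to compound 3 (beyond the scatter). The 2-chlorophenyl group does not set the outcome alone, since hydrogen in place of methyl on the saturated chain carbon, with that group kept, still brings a modest change, a number 25 percentage points lower from compound 1 to compound 3 (beyond the scatter). No measurement at hand explains why either change acts as it does.

Still open, on these data alone, is whether the fall follows the chlorine atom or its place on the aromatic ring, which a 4-chlorophenyl or 2-fluorophenyl group on the same nitrogen could separate. It is also unclear how an unsubstituted phenyl group there, or a longer chain on the chain carbon, would fare.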